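The compounds below may be only part of what the source reports. "The series", "measured", "known", "first", "only" and "open" are said of these compounds alone.

Measured so far:
- compound 1 `CCCCc1cnc(C(CCC)Cc2ccc(-c3ccccc3C(=O)O)cc2)[nH]1` — 1180 nM
- compound 2 `O=C(O)c1ccccc1-c1ccc(CCc2ncc(CC3CCC3)[nH]2)cc1` — 588 nM

Both values come from an in vitro functional assay on cells for agonist activity at Bombesin receptor subtype-3 (Homo sapiens), read by luminescence and calcium flux; a lower number here means that less compound is needed, a higher number that more compound is needed for the effect. Compound 1 gives 1180 nM there, and compound 2 gives 588 nM; the gap between the two lies within the usual scatter of this assay, so the two numbers cannot be told apart and neither compound can be called the more active.

Compound 3 `CCCCc1cnc(C(Cc2ccc(-c3ccccc3C(=O)O)cc2)C(C)C)[nH]1` has not been measured. It keeps every atom of compound 1 and rejoins them: isopropyl in place of propyl on a saturated chain carbon bound to an aromatic carbon and a saturated chain carbon. The acid-bearing biaryl and the shared core are untouched, and the total count of atoms is unchanged.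

No pair of measured compounds differs in only one place, so there is no shown step to lean on for this change. A change of this kind, a rearrangement of a small alkyl branch at the same position, is expected to move the number little: none beyond the scatter, in either direction, with the estimated step from compound 1 to compound 3 being a 1.0-fold higher number from compound 1 to compound 3 (0.01 log units; within the scatter). Compound 3 is therefore expected to give about 1200 nM in this assay, with a range from 400 nM to 3600 nM.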

Compound 3, half-maximal effective concentration: 4620 nM
The estimate for compound 3 lay 3.9-fold (0.59 log units) below the measured number, and the stated range ends below it.
By their numbers in this assay, from the lowest: compounds 2 and 1 (each within the scatter of the next); then compound 3.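

In this assay, among these compounds, isopropyl in place of propyl on a saturated chain carbon bound to an aromatic carbon and a saturated chain carbon gives a 3.9-fold higher number from compound 1 to compound 3 (0.59 log units; beyond the scatter) and is the first step that lies beyond the scatter. Compound 1 and compound 3 hold the same atoms, so this position responds to how its three carbons are joined, not only to how many there are. Nothing shown bears on why the number moves.

Going by these compounds, this is one step on one background, so it remains open whether the same change would give a step of similar size elsewhere. Also open, on these data alone, is how a tert-butyl group, a cyclopropyl group or a longer chain on this carbon would compare with propyl and isopropyl.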